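Adding Chlorine to a Series Without Measured Cytotoxicity

The compounds below may be only part of what the source reports. "The series", "measured", "known", "first", "only" and "open" are said of these compounds alone.

Of the compounds shown here, two have so far been tested in a functional assay on DU-145 cells (Homo sapiens) for cytotoxicity, read by MTT assay; on this read-out higher numbers stand for weaker inhibition and lower numbers for stronger inhibition. Compound 1, `CC(O)(CSc1ccc(F)cc1)c1nc(-c2ccccc2)no1`, carries a fluoro group on one of its aromatic rings. In this assay compound 1 gives > 100000 nM, which is a limit of the assay rather than a number. Compound 2, `CC(O)(CSc1ccccc1)c1nc(-c2ccccc2)no1`, has hydrogen in place of that fluoro. In this assay compound 2 gives > 100000 nM, again a limit and not a number. The step that the two limits leave unreadable from compound 1 to compound 2 cannot be sized because both values sit at the limit of > 100000 nM in this assay, at which 2 of the 2 values shown sit. Compound 2 therefore stands only at the limit, with no measured number for it.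

Compound 3, `CC(O)(CSc1ccccc1)c1nc(-c2ccc(Cl)cc2)no1`, differs from compound 2 by chloro in place of hydrogen on an aromatic carbon. Going by the values given here, no measured step bears on this change, and the single measured step is itself unreadable, so there is no basis for expecting a gain or a loss. Compound 3 is expected to remain near the limit, with an estimated value of 100000 nM in a range from 30000 nM to 300000 nM. The expected step from compound 2 to compound 3 is thus a number no higher from compound 2 to compound 3 (the limit leaves the size open), most likely still reported as a limit.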

Compound 3, half-maximal inhibitory concentration: 4500 nM
Beside the measured number, compound 3's estimate is 22-fold (1.35 log units) above it; measured number below the stated range.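

Replacing phenyl with 4-chlorophenyl brings an at least 22-fold lower number from compound 2 to compound 3 (1.34 log units; beyond the scatter) in this assay, and a lower number here means stronger inhibition. This is the only readable step among the compounds shown, and it establishes that a single chloro, para to a large group, is enough to bring this series to a measurable value. The earlier step changed a different aromatic ring and could not be read, so it gave no sign that any position in the series could shift the result. The true size of the new step remains open, and the figure is only a lower bound because compound 2 has no exact number of its own: the limit of > 100000 nM in this assay, at which 2 of the 3 values shown sit.

The compounds shown leave open whether the gain belongs to chloro specifically or would also appear with another group at this position, such as bromo, methyl, methoxy or an amine. They also leave open whether a chloro on the other aromatic ring, the one that carries the fluoro in compound 1, would have any comparable effect.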